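A Methoxy Swap on the Propyl Chain of Compound 3

The compounds below may be only part of what the source reports. "The series", "measured", "known", "first", "only" and "open" are said of these compounds alone.

Three compounds that share one core and differ only in a side chain have been measured in a functional assay on OVCAR-8 cells (Homo sapiens) for antiproliferative activity; a lower number here means a stronger inhibitor, a higher number a weaker inhibitor. There compound 1 `Cn1ncc(Cl)c1-c1cc(C(=O)N[C@@H]2CN[C@H](CCn3cncn3)C[C@H]2c2ccc(Cl)c(Cl)c2)oc1Cl` gives 1560 nM and compound 2 `Cn1ncc(Cl)c1-c1cc(C(=O)N[C@@H]2CN[C@H](CC(N)=O)C[C@H]2c2ccc(Cl)c(Cl)c2)oc1Cl` gives 1000 nM while compound 3 `CCC[C@@H]1C[C@@H](c2ccc(Cl)c(Cl)c2)[C@H](NC(=O)c2cc(-c3c(Cl)cnn3C)c(Cl)o2)CN1` gives 1620 nM in the same read-out. Compound 3 thus stands level with the other two, and nothing separates the three beyond the scatter.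

Compound 4 `COCC[C@@H]1C[C@@H](c2ccc(Cl)c(Cl)c2)[C@H](NC(=O)c2cc(-c3c(Cl)cnn3C)c(Cl)o2)CN1` differs from compound 3 in one place, with methoxy in place of methyl on a saturated chain carbon, two bonds along the chain from a saturated ring carbon so that propyl becomes 2-methoxyethyl.

The measured steps in this same side chain bear on the change. Methyl in place of 1H-1,2,4-triazol-1-yl gave a 1.0-fold higher number from compound 1 to compound 3 (0.02 log units; within the scatter) and ethyl in place of carbamoyl gave a 1.6-fold higher number from compound 2 to compound 3 (0.21 log units; within the scatter) while carbamoyl in place of (1H-1,2,4-triazol-1-yl)methyl gave a 1.6-fold lower number from compound 1 to compound 2 (0.19 log units; within the scatter) as the third comparison. None of these steps leaves the scatter, so none beyond it is expected here and no direction is favoured. The expected step is a 1.2-fold lower number from compound 3 to compound 4 (0.06 log units; within the scatter) in this assay on this reading. Compound 4 is therefore estimated at 1400 nM (expected range from 700 nM to 2800 nM).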

Compound 4, half-maximal inhibitory concentration: 1060 nM
The estimate for compound 4 lay 1.3-fold (0.12 log units) above the measured number; low and high end bracket the measured number.
By their numbers in this assay, from the lowest: compounds 2, 4, 1 and 3 (each within the scatter of the next).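

In this assay, the step with methoxy in place of methyl on a saturated chain carbon, two bonds along the chain from a saturated ring carbon, is a 1.5-fold lower number from compound 3 to compound 4 (0.18 log units; within the scatter), so bringing in one hydrogen-bond acceptor at this place does not take the number outside the scatter. The other two comparisons read the same way: methoxymethyl in place of carbamoyl gives a 1.1-fold higher number from compound 2 to compound 4 (0.03 log units; within the scatter), and methoxy in place of 1H-1,2,4-triazol-1-yl gives a 1.5-fold lower number from compound 1 to compound 4 (0.17 log units; within the scatter), which places the 2-methoxyethyl chain level with the propyl, carbamoyl-bearing and triazole-bearing side chains, with nothing separating the four. The compounds shown come with no evidence that could account for this flat read-out at the position.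

Among these compounds, still open is whether a primary amine or a carboxylic acid at the end of this chain, or a chain longer than propyl, would produce the first step here that lies beyond the scatter. On these data alone, it also remains open whether the methoxy for methyl exchange would read the same way on a core other than the one shared by these four compounds.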